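The source may hold more compounds than are shown below. What is called first, only, known or untested is meant among the compounds shown, and "the series" means these compounds.

Measured: compound 1 `O=C(Nc1cccc(-n2cc(-c3ccncc3)c(-c3ccc(Cl)c(O)c3)n2)c1)Nc1cccc(C(F)(F)F)c1` with 1340 nM; compound 2 `COc1cc(-c2nn(-c3cccc(NC(=O)Nc4cc(C(F)(F)F)cc(C(F)(F)F)c4)c3)cc2-c2ccncc2)ccc1Cl` with 933 nM.

In a functional assay on MCF7 cells (Homo sapiens) for inhibition, read by sulforhodamine B assay, with a stated time of 48 h (a higher number here means a weaker inhibitor of growth, a lower number a stronger inhibitor of growth), compound 1 gives 1340 nM and compound 2 gives 933 nM; the two numbers lie within the usual scatter of each other, so no order between compound 1 and compound 2 can be read. Compound 3 `O=C(Nc1cccc(-n2cc(-c3ccncc3)c(-c3ccc(Cl)c(O)c3)n2)c1)Nc1cc(C(F)(F)F)cc(C(F)(F)F)c1` is not yet measured and differs from compound 2 by hydrogen in place of methyl on an oxygen on an aromatic ring. Among the measured compounds shown here, no measured pair isolates this change, so no step can be quoted. With compound 2 at 933 nM and the hydroxy-bearing compound 1 at 1340 nM, no move beyond the scatter is expected. Compound 3 is estimated at 1000 nM, range 400 nM to 2500 nM, a step of a 1.1-fold higher number from compound 2 to compound 3 (0.03 log units; within the scatter) expected to stay within the scatter.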

Compound 3, concentration for 50% growth inhibition: 540 nM
For compound 3 the middle estimate is 1.9-fold (0.27 log units) above the measured one, and the stated range covers the measured number.
By their numbers in this assay, from the lowest: compounds 3, 2 and 1 (each within the scatter of the next, the first and the last beyond it).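

In this assay, the methoxy to hydroxy change now has a matched pair: a 1.7-fold lower number from compound 2 to compound 3 (0.24 log units; within the scatter), so this exchange on the 4-chloro-3-methoxyphenyl group shows no readable effect. Trifluoromethyl in place of hydrogen on an aromatic carbon gives a 2.5-fold lower number from compound 1 to compound 3 (0.39 log units; beyond the scatter), the only modest move that clears the scatter here. Nothing available explains either step. On these data alone, whether an amine or a carboxylic acid in place of the hydroxy, or a longer chain on that oxygen, would shift growth inhibition stays open. As far as these compounds go, whether the trifluoromethyl step carries over to methoxy compounds also stays open.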